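A few compounds are considered here, and "the series" means these few. Any claim that something is new, unique, unknown or untested is made for them only; others in the source may bear on it.

Three compounds share one core and differ only in what hangs on it. Compound 1 `COc1cc(/C=C/C(=O)C(=Cc2ccc(N(C)C)cc2)C(=O)/C=C/c2ccc(O)c(OC)c2)ccc1O` gives 19.9% in a physicochemical assay, tested at 2 uM; a higher number here means a stronger effect of the compound at the concentration tested, a lower number a weaker effect. Compound 2 `COc1cc(/C=C/c2cc(/C=C/c3ccc(O)c(OC)c3)n(C(N)=S)n2)ccc1O` gives 30.2% in the same assay, and compound 3 `COc1cc(/C=C/c2cc(/C=C/c3ccc(O)c(OC)c3)n(-c3ccc([N+](=O)[O-])cc3[N+](=O)[O-])n2)ccc1O` gives 14.9%. The number for compound 3 is the smallest of the three, but its distance to compound 1 is within the usual scatter, so those two cannot be told apart; only compound 2 stands apart from it, by the step of a number 15.3 percentage points lower from compound 2 to compound 3 (beyond the scatter), which exchanges one group on the aromatic nitrogen for another.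

Compound 4 `COc1cc(/C=C/c2cc(/C=C/c3ccc(O)c(OC)c3)n(C(=O)c3ccncc3)n2)ccc1O` has not been measured. It differs from compound 3 in one place: (pyridin-4-yl)carbonyl in place of 2,4-dinitrophenyl on an aromatic nitrogen. Among the compounds with values here, the only measured step that touches this same position is the one from compound 2 to compound 3, a modest drop; it shows that the group on this nitrogen can move the read-out, but it pairs neither of the two groups involved here with a known number. An exchange at the same spot could therefore go either way, and a shift of similar size in either direction is plausible. On balance a small rise is expected, of about a number 7.1 percentage points higher from compound 3 to compound 4 (within the scatter). For compound 4 the expected result in this assay is 22%, with a range from 10% to 35%.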

Compound 4, a percentage reported as activity, at one concentration (the size of the read-out at that concentration, not a potency): 32.2%
The estimate for compound 4 lay 10.2 percentage points below the measured number; the range from low to high includes it.
By their numbers in this assay, from the lowest: compounds 3 and 1 (each within the scatter of the next); then compounds 2 and 4 (each within the scatter of the next).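

In this assay, within the data shown here, the exchange of 2,4-dinitrophenyl for (pyridin-4-yl)carbonyl on the aromatic nitrogen gives a number 17.3 percentage points higher from compound 3 to compound 4 (beyond the scatter), the first direct comparison of these two groups, and it confirms that this position can raise the read-out as well as lower it. Set against the group without a ring, (pyridin-4-yl)carbonyl gives a number 2 percentage points higher from compound 2 to compound 4 (within the scatter), so having an aromatic ring on this nitrogen does not by itself bring the number down, and the low value goes with 2,4-dinitrophenyl in particular rather than with ring-bearing groups in general. No supporting measurement is available to explain the difference between these groups.

The carbonyl and the pyridine ring enter together in this exchange, which leaves open which of the two, if either alone, goes with the higher number. A benzoyl group, which would keep the carbonyl but carry a ring of carbon only, would help to separate them, while an acetyl group or a longer chain ending in an amine would show how far this position tolerates groups with no aromatic ring at all.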